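From Sulfoxide to Tetrazole Amide at the Chain End

The source may hold more compounds than are shown below. What is called first, only, known or untested is meant among the compounds shown, and "the series" means these compounds.

Of the compounds shown here, three that share one core have been measured in an assay on isolated protein for inhibition of leukotriene B4 receptor 1 (Homo sapiens), tested at 10 uM; on this read-out higher numbers stand for more inhibition at the one concentration tested (going by the name of the read-out) and lower numbers for less inhibition. Compound 1 `CCc1cc(C(C)=O)c(O)cc1OCCCCCCC#N` gives 103%. Compound 2 `CCc1cc(C(C)=O)c(O)cc1OCCCCCC(C)(C)C#N` gives 85%. Compound 3 `CCc1cc(C(C)=O)c(O)cc1OCCCCCC[S+](C)[O-]` gives 92%. Within this set compound 3 stands second highest: it sits a number 11 percentage points lower from compound 1 to compound 3 (beyond the scatter), while the step of a number 7 percentage points higher from compound 2 to compound 3 (within the scatter) is within the scatter, so compound 2 and compound 3 cannot be told apart.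

Compound 4 `CCc1cc(C(C)=O)c(O)cc1OCCCCCCC(=O)Nc1nn[nH]n1` has not yet been measured in this assay. It differs from compound 3 only at the end of the chain: a group of 8 heavy atoms (2 carbon, 5 nitrogen, 1 oxygen; one five-membered aromatic ring with 4 hetero atoms) in place of a group of 3 heavy atoms (1 carbon, 1 oxygen, 1 sulfur; no ring), on a saturated chain carbon, six bonds along the chain from an oxygen on an aromatic ring. Going by the values given here, the steps that bear on this change are those at the same chain end. The exchange of the nitrile for the sulfoxide, a number 11 percentage points lower from compound 1 to compound 3 (beyond the scatter), cost a modest amount, and the exchange of the larger nitrile group for the sulfoxide, a number 7 percentage points higher from compound 2 to compound 3 (within the scatter), changed nothing beyond the scatter. Every end group tried so far keeps inhibition high. For compound 4, a step of a number 2 percentage points lower from compound 3 to compound 4 (within the scatter) is therefore expected, lying within the scatter. The estimated value for compound 4 is 90%, expected to fall between 72% and 104%.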

Compound 4, a percentage reported as inhibition, at one concentration (the size of the read-out at that concentration, not a potency): 101%
Beside the measured number, compound 4's estimate is 11 percentage points below it, within the range that was stated.
By their numbers in this assay, from the lowest: compounds 2, 3, 4 and 1 (each within the scatter of the next, the first and the last beyond it).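

In this assay the chain end takes the far larger (2H-tetrazol-5-yl)carbamoyl group, with its five-membered aromatic ring, and a number 9 percentage points higher from compound 3 to compound 4 (within the scatter) and a number 2 percentage points lower from compound 1 to compound 4 (within the scatter) show no difference that can be told from the scatter. Only against the branched nitrile does the new group stand apart, with a number 16 percentage points higher from compound 2 to compound 4 (beyond the scatter) on record, so a ring-bearing amide fits at this position as well as the plain nitrile does. Nothing at hand explains why inhibition stays this high with so large a group.

Going by these compounds, whether the tetrazole ring or the amide that carries it matters more stays open, and a carboxylic acid or a simple primary amide at this chain end would help separate the two. On these data alone, with a single test concentration and all numbers high, these compounds also cannot be ranked by potency, and the effect of a shorter chain remains unknown.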